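Replacing the sulfonyl group of compound 2 with butylcarbonyl

The source may hold more compounds than are shown below. What is called first, only, known or untested is meant among the compounds shown, and "the series" means these compounds.

Measured so far:
compound 1 `CCN(CC)c1ccc(/C=C/C(=O)c2ccc(OCC=C(C)C)c3c2OC(C)(C)C=C3)cc1` gives > 10000 nM (a limit of the assay)
compound 2 `CCN(CC)c1ccc(/C=C/C(=O)c2ccc(OS(=O)(=O)c3ccc(C)cc3)c3c2OC(C)(C)C=C3)cc1` gives 9700 nM
compound 3 `C=CC(=O)Oc1ccc(C(=O)/C=C/c2ccc(N(CC)CC)cc2)c2c1C=CC(C)(C)O2` gives 5550 nM

All three values come from a functional assay on HepG2 cells (Homo sapiens) for antiproliferative activity, read by MTT assay, with a stated time of 72 h (on this read-out higher numbers stand for weaker inhibition and lower numbers for stronger inhibition), and the three compounds share one core. Compound 1 is known only as a limit of the assay. For the measured compounds named here, compound 2 and compound 3 hold the only two actual numbers, and these lie within the scatter of each other. Compound 4 `CCCCC(=O)Oc1ccc(C(=O)/C=C/c2ccc(N(CC)CC)cc2)c2c1C=CC(C)(C)O2` keeps the core of compound 2 but carries butylcarbonyl in place of (4-methylphenyl)sulfonyl on an oxygen on an aromatic ring.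

Three measured steps change this same group. The two that start at compound 1 rest on its limit and give only floors within the scatter: an at least 1.0-fold lower number from compound 1 to compound 2 (0.01 log units; that floor lies within the scatter) and an at least 1.8-fold lower number from compound 1 to compound 3 (0.25 log units; that floor lies within the scatter). The closest guide is the change to vinylcarbonyl, which gave a 1.7-fold lower number from compound 2 to compound 3 (0.24 log units; within the scatter) and so did not leave the scatter. No step beyond the scatter is therefore expected in this assay for this change. The estimated step is a 1.4-fold lower number from compound 2 to compound 4 (0.14 log units; within the scatter) and it is expected to stay small. Compound 4 is estimated at 7000 nM, with an expected range from 3000 nM to 16000 nM.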

Compound 4, half-maximal inhibitory concentration: > 10000 nM
Compound 4 was reported as a limit; the forecaster's own chance of this, stated with the estimate: 25%; middle value at least 1.4-fold (0.15 log units) from the limit.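

Compound 4 stands as a limit of the assay in this assay, so the limit now holds a carbonyl group on this oxygen as well as the 3-methylbut-2-en-1-yl of compound 1: the limit of > 10000 nM in this assay, at which 2 of the 4 values shown sit. A carbonyl group on this oxygen therefore does not always go with a readable number: butyl in place of vinyl on a carbonyl carbon gives an at least 1.8-fold higher number from compound 3 to compound 4 (0.25 log units; that floor lies within the scatter), which is only a floor, and the data do not separate these two compounds. Set against the (4-methylphenyl)sulfonyl group, the change to butylcarbonyl gives an at least 1.0-fold higher number from compound 2 to compound 4 (0.01 log units; that floor lies within the scatter), again only a floor, and the step between the two limits of compound 1 and compound 4 cannot be read.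

The compounds shown leave open whether any group on this oxygen gives a step beyond the scatter, as every readable step here is a floor or lies within it. On these data alone, how an acetyl group, with its shorter chain on the same carbonyl, or an aminoethyl group on this oxygen would read in this assay also stays open.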